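This account rests on a few compounds, and the source may have more. Where it says the series, first, only, none or still open, it means among the compounds named here.

In a functional assay on SK-BR-3 cells (Homo sapiens) for antiproliferative activity, read by MTT assay, with a stated time of 72 h (a higher number here means a weaker inhibitor, a lower number a stronger inhibitor), compound 1 `C/C=C1/[C@H](O[C@@H]2O[C@H](COC(C)=O)[C@@H](OC(C)=O)[C@H](OC(C)=O)[C@H]2OC(C)=O)OC=C(C(=O)OC)[C@H]1CC(=O)OCCC` gives 6600 nM. Compound 2 `C/C=C1/[C@H](O[C@@H]2O[C@H](COC(C)=O)[C@@H](OC(C)=O)[C@H](OC(C)=O)[C@H]2OC(C)=O)OC=C(C(=O)O)[C@H]1CC(=O)OC` reaches only the limit of the assay, > 20000 nM, which is not a number. Compound 3 `C/C=C1/[C@H](O[C@@H]2O[C@H](CO)[C@@H](O)[C@H](O)[C@H]2O)OC=C(C(=O)OC)[C@H]1CC(=O)OCCc1ccc(OC)c(OC)c1` likewise gives only a limit, > 15000 nM. Compound 3 therefore stands at one of two limits among the three values shown, and compound 1 alone gives a number in this assay. Compound 4 `C/C=C1/[C@H](O[C@@H]2O[C@H](CO)[C@@H](O)[C@H](O)[C@H]2O)OC=C(C(=O)OC)[C@H]1CC(=O)OCc1ccco1` differs from compound 3 in one place: furan-2-yl in place of 3,4-dimethoxybenzyl on a saturated chain carbon bound to an oxygen next to a carbonyl group. Among the compounds with values here, no measured step covers a change of this kind, so the expected step in this assay is a number no higher from compound 3 to compound 4 (the limit leaves the size open), which is nothing beyond the usual scatter. Compound 4 is accordingly estimated at 15000 nM, with a range from 5000 nM to 40000 nM.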

Compound 4, half-maximal inhibitory concentration: > 15000 nM
Compound 4: only a limit was reported (the forecaster's own chance of this, stated with the estimate: 50%); the middle value lies on the limit itself.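

Compound 3 and compound 4 both give only a limit in this assay, not a number, so no step can be read between them. The compounds shown leave open whether furan-2-yl in place of 3,4-dimethoxybenzyl changes activity at all.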